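A few compounds are considered here, and "the series" means these few. Any claim that something is new, unique, unknown or untested is made for them only; others in the source may bear on it.

This account follows a short series that shares one core and was measured in a physicochemical assay for permeability, using PAMPA, at pH 7.4; on this read-out lower numbers stand for lower permeability and higher numbers for higher permeability. Compound 1 `CC(C)(C)OC(=O)NCCS(=O)(=O)NC(=O)c1ccc(Nc2nc(NC3(c4ccc(Cl)cc4)CC3)nc(OCC(F)(F)F)n2)cc1` gives 111 nm/s, the highest of the three numbers on hand. Compound 2 `CC(C)NC(=O)NCCS(=O)(=O)NC(=O)c1ccc(Nc2nc(NC3(c4ccc(Cl)cc4)CC3)nc(OCC(F)(F)F)n2)cc1` gives 45 nm/s, and compound 3 `CNC(=O)NCCS(=O)(=O)NC(=O)c1ccc(Nc2nc(NC3(c4ccc(Cl)cc4)CC3)nc(OCC(F)(F)F)n2)cc1` gives 40 nm/s. The step of a 2.5-fold lower number from compound 1 to compound 2 (0.39 log units; beyond the scatter) and the step of a 2.8-fold lower number from compound 1 to compound 3 (0.44 log units; beyond the scatter) both lie beyond the scatter, whereas the step of a 1.1-fold lower number from compound 2 to compound 3 (0.05 log units; within the scatter) does not.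

The unmeasured compound 4 `NCCS(=O)(=O)NC(=O)c1ccc(Nc2nc(NC3(c4ccc(Cl)cc4)CC3)nc(OCC(F)(F)F)n2)cc1` differs from compound 1 in a single place: hydrogen in place of tert-butoxycarbonyl on an amine nitrogen. The two measured steps from compound 1 bear on this change, as each of them also replaces tert-butoxy on a carbonyl carbon while the carbonyl itself stays; in compound 4 the whole tert-butoxycarbonyl leaves and only hydrogen enters on the amine nitrogen. Those two steps were modest in size, and the present change removes more than either of them did, so the step from compound 1 to compound 4 is expected to be larger than both, estimated as a 14-fold lower number from compound 1 to compound 4 (1.14 log units; beyond the scatter). Compound 4 is therefore expected to give about 8 nm/s in this assay, with a likely range from 2 nm/s to 30 nm/s.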

Compound 4, apparent permeability: 153 nm/s
The estimate for compound 4 lay 19-fold (1.28 log units) below the measured number; the whole stated range lies below it.
By their numbers in this assay, from the lowest: compounds 3 and 2 (each within the scatter of the next); then compounds 1 and 4 (each within the scatter of the next).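

In this assay, hydrogen in place of tert-butoxycarbonyl on the amine nitrogen leaves the number within the scatter (a 1.4-fold higher number from compound 1 to compound 4 (0.14 log units; within the scatter)), so the 2-aminoethyl and 2-((tert-butoxycarbonyl)amino)ethyl chains cannot be told apart in this read-out. The earlier steps had shown only that the two carbamoyl groups gave lower numbers than tert-butoxycarbonyl, whereas the same nitrogen carrying only hydrogen now stands clearly above both of them (a 3.8-fold higher number from compound 3 to compound 4 (0.58 log units; beyond the scatter); a 3.4-fold higher number from compound 2 to compound 4 (0.53 log units; beyond the scatter)), so the number does not simply follow how much is removed at this position. Nothing measured on these compounds accounts for this behaviour.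

The compounds shown leave open whether a small acyl group such as acetyl, or a single methyl on the same amine nitrogen, would group with compound 1 and compound 4 or with compound 2 and compound 3 in this assay. They also leave open whether a carboxylic acid in place of the amine, or a chain longer than 2-aminoethyl, would keep a number close to that of compound 4 (153 nm/s).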